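A few compounds are considered here, and "the series" means these few. Any claim that something is new, unique, unknown or untested is made for them only; others in the source may bear on it.

The measured compounds:
Compound 1 `CN1CCC[C@@H]1Cn1nc(Cc2cccc(F)c2)c2ccccc2c1=O` gives 50.1 nM in an assay for binding affinity to Alpha-1A adrenergic receptor (Homo sapiens); on this read-out lower numbers stand for stronger inhibition and higher numbers for weaker inhibition.
Compound 2 `CN1CCC[C@@H]1Cn1nc(Cc2ccc(F)cc2)c2ccccc2c1=O` gives 63.1 nM in this assay.
Compound 3 `CN(C)CCn1nc(Cc2ccc(Cl)cc2)c2ccccc2c1=O` gives 158 nM in this assay.

Compound 1 has the lowest of the three numbers in this assay. Among the compounds with values here, compound 2 is nearest to it, with a 1.3-fold higher number from compound 1 to compound 2 (0.10 log units; within the scatter), and compound 3 is furthest, its number higher by a margin beyond the scatter, though no single-place step connects compound 3 to compound 1, since the two differ both in the chain and in the halogen on the ring.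

Compound 4 `COc1cccc(Cc2nn(C[C@H]3CCCN3C)c(=O)c3ccccc23)c1` has not yet been measured in this assay. It differs from compound 1 in one place: methoxy in place of fluoro on an aromatic carbon. Within the data shown here, none of the measured steps exchanges fluoro for methoxy. Among the measured compounds shown here, the one step that touches this ring is the change from compound 1 to compound 2, a 1.3-fold higher number from compound 1 to compound 2 (0.10 log units; within the scatter), in which the fluoro moved to another carbon of the same ring and the number stayed within the scatter. That is thin ground: it shows the ring accepts a shift of the fluoro, but nothing measured here carries a methoxy. The expectation is therefore a step of a 1.2-fold higher number from compound 1 to compound 4 (0.08 log units; within the scatter), not beyond the scatter, with a wide range around it. Compound 4 is estimated at 60 nM, between 25 nM and 160 nM.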

Compound 4, inhibition constant: 1580 nM
The estimate for compound 4 lay 26-fold (1.42 log units) below the measured number, outside the stated range (above it).
By their numbers in this assay, from the lowest: compounds 1 and 2 (each within the scatter of the next); then compound 3; then compound 4.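

In this assay the exchange of 3-fluorophenyl for 3-methoxyphenyl is a large step (a 32-fold higher number from compound 1 to compound 4 (1.50 log units; beyond the scatter)), which shows that this aromatic carbon is sensitive to the identity of its group in a way the earlier shift of the fluoro did not reveal. The step from the 4-fluorophenyl compound is of similar size (a 25-fold higher number from compound 2 to compound 4 (1.40 log units; beyond the scatter)), so the loss in this assay does not depend on which of the two fluorinated compounds serves as the reference. The change itself is small when counted, with one fluorine leaving and one carbon and one oxygen entering, including one hydrogen-bond acceptor, and nothing available here accounts for the size of the step.

The compounds shown do not tell whether a chloro, methyl or hydroxy group on the same aromatic carbon would stay close to the fluoro compounds or fall with the methoxy compound. They also leave open whether methoxy in place of halogen would cost as much on the dimethylaminoethyl-type chain of compound 3 as it does with the chain of compound 1.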